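This account rests on a few compounds, and the source may have more. Where it says the series, first, only, none or still open, it means among the compounds named here.

Working notes on the series, read in a functional assay on A549 cells (Homo sapiens) for inhibition, read by MTT assay, with a stated time of 72 h; on this read-out lower numbers stand for stronger inhibition and higher numbers for weaker inhibition. Compound 1 (`Nc1nc2cc(-c3nn(CCCC(=O)NO)c4ncnc(N)c34)ccc2o1`) gives > 100000 nM, which is a limit. Compound 2 (`Nc1nc2cc(-c3nn(CCCCC(=O)NO)c4ncnc(N)c34)ccc2o1`) gives > 100000 nM, also a limit. Among the compounds with values here, compound 3 (`Nc1nc2cc(-c3nn(CCCCCCCCC(=O)NO)c4ncnc(N)c34)ccc2o1`) gives 13200 nM, the only actual number so far. Compound 4 (`CNC(=O)CCCCCCCn1nc(-c2ccc3oc(N)nc3c2)c2c(N)ncnc21`) differs from compound 3 by methylcarbamoyl in place of (hydroxycarbamoyl)methyl on a saturated chain carbon, seven bonds along the chain from an aromatic nitrogen: methylcarbamoyl in place of (hydroxycarbamoyl)methyl. The readable steps, an at least 7.5-fold lower number from compound 1 to compound 3 (0.87 log units; beyond the scatter) and an at least 7.5-fold lower number from compound 2 to compound 3 (0.87 log units; beyond the scatter), change chain length with the hydroxycarbamoyl end kept, so neither tests this replacement directly. Given that compound 3 alone has left (the limit of > 100000 nM in this assay, at which 2 of the 3 values shown sit), with 13200 nM, a loss is expected rather than a gain. The expected step is a 3.8-fold higher number from compound 3 to compound 4 (0.58 log units; beyond the scatter), towards weaker inhibition. Compound 4 is estimated at 50000 nM, within a range of 15000 nM to 150000 nM.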

Compound 4, half-maximal inhibitory concentration: 8360 nM
Compound 4: middle estimate off by 6.0-fold (0.78 log units), on the high side; the measured number lies below the stated range.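

In this assay methylcarbamoyl in place of (hydroxycarbamoyl)methyl, on a saturated chain carbon, seven bonds along the chain from an aromatic nitrogen, gives a 1.6-fold lower number from compound 3 to compound 4 (0.20 log units; within the scatter) and thus no readable change, so a hydroxycarbamoyl end is not required for activity in this range. The comparisons with the shorter hydroxycarbamoyl chains, an at least 11-fold lower number from compound 2 to compound 4 (1.07 log units; beyond the scatter) and an at least 11-fold lower number from compound 1 to compound 4 (1.07 log units; beyond the scatter), start from limits and give minimum sizes only: the limit of > 100000 nM in this assay, at which 2 of the 4 values shown sit.

On these data alone, whether methylcarbamoyl on the shorter chains of compound 1 and compound 2 would read the same stays open, as does the effect of a carboxylic acid or a longer chain at this end.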